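This account rests on a few compounds, and the source may have more. Where it says the series, first, only, none or still open, it means among the compounds named here.

For the measured compounds named here, the two compounds measured so far share a core built around an aromatic ring that carries a carboxylic acid, an amine bearing a saturated chain, and a sulfonamide. Compound 1 is `CCCCCCNc1ccc(C(=O)O)cc1S(N)(=O)=O` and compound 2 is `CCCCNc1ccc(C(=O)O)cc1S(=O)(=O)N(C)C`. In an assay on HEK293 cells for inhibition of solute carrier family 12 member 2 (Homo sapiens), read by fluorescence, with a stated time of 30 min, tested at 100 uM (on this read-out lower numbers stand for a weaker effect and higher numbers for a stronger effect at the one concentration tested), compound 1 gives 4.9%, while compound 2 gives 15.6%. Compound 2 thus stands highest of the two numbers shown, and its gap to compound 1 lies beyond the usual scatter. The two compounds differ in two places at once, so their values alone do not tell which difference matters.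

Compound 3 is `CCCCCCNc1ccc(C(=O)O)cc1S(=O)(=O)N(C)C`. It keeps the dimethyl sulfonamide of compound 2 and differs from it by ethyl in place of hydrogen on a saturated chain carbon, four bonds along the chain from a nitrogen on an aromatic ring. Going by the values given here, no pair of measured compounds differs in this one place alone, so there is no measured step of this kind to lean on. Compound 1 carries the longer chain with the other sulfonamide and sits low, which gives no firm guide. For compound 3 the step of a number 1.6 percentage points lower from compound 2 to compound 3 (within the scatter) is expected to stay within the scatter. Compound 3 is therefore estimated at 14%, with a range from 3% to 30%.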

Compound 3, a percentage reported as inhibition, at one concentration (the size of the read-out at that concentration, not a potency): 19.8%
Compound 3: middle estimate off by 5.8 percentage points, on the low side; the range from low to high includes it.
By their numbers in this assay, from the lowest: compound 1; then compounds 2 and 3 (each within the scatter of the next).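

In this assay, ethyl in place of hydrogen on a saturated chain carbon, four bonds along the chain from a nitrogen on an aromatic ring, gives a number 4.2 percentage points higher from compound 2 to compound 3 (within the scatter), so with dimethylamino on the sulfonyl sulfur, this change in chain length shows no clear effect. Dimethylamino in place of amino on the sulfonyl sulfur gives a number 14.9 percentage points higher from compound 1 to compound 3 (beyond the scatter), so this is the only single change shown here that reaches beyond the scatter, although it has been read only on the longer chain of compound 1 and compound 3. The compounds shown offer no independent measurement that could explain either step.

From the compounds shown here alone, it remains open whether the gain from dimethylamino on the sulfonyl sulfur would also appear with the shorter chain of compound 2, and whether a larger group there, such as diethylamino, would move the number further. Going by these compounds, it is also open whether a longer chain such as octyl would stay level with compound 3, and how much the carboxylic acid contributes compared with a replacement such as a primary amide.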